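Phenyl to methyl at the carbonyl of compound 1

A few compounds are considered here, and "the series" means these few. Any claim that something is new, unique, unknown or untested is made for them only; others in the source may bear on it.

Going by the values given here, compound 1 `Nc1ccc(Cl)cc1C1=NN(C(=O)c2ccccc2)CC1` gives 17% in an assay on isolated protein for inhibition of Nitric oxide synthase, inducible (Homo sapiens), with a stated time of 30 min, tested at 1 mM (a higher number here means more inhibition at the concentration tested (going by the name of the read-out), a lower number less inhibition), the second highest of the three numbers measured so far. Compound 2 `COc1ccc(N)c(C2=NN(C(=O)c3ccccc3)CC2)c1` gives 12.2%, a step of a number 4.8 percentage points lower from compound 1 to compound 2 (within the scatter). Compound 3 `Nc1cc(Cl)c(Cl)cc1C1=NN(C(=O)c2ccccc2)CC1` gives 36.1%, a step of a number 19.1 percentage points higher from compound 1 to compound 3 (beyond the scatter). Compound 4 `CC(=O)N1CCC(c2cc(Cl)ccc2N)=N1` differs from compound 1 in a different place: methyl in place of phenyl on a carbonyl carbon. Both measured steps changed a group on the aromatic ring and left the carbonyl untouched, so neither bears on this change, and the data give no guide to what the phenyl contributes. With nothing to point either way, the expected step is none beyond the scatter, so the estimated step is a number 2 percentage points lower from compound 1 to compound 4 (within the scatter). Compound 4 is therefore estimated at 15%, with a range from 3% to 32%.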

Compound 4, a percentage reported as inhibition, at one concentration (the size of the read-out at that concentration, not a potency): 1.03%
Compound 4: the middle estimate sits 14 percentage points above what was measured; measured number below the stated range.
By their numbers in this assay, from the lowest: compound 4; then compounds 2 and 1 (each within the scatter of the next); then compound 3.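

Swapping phenyl for methyl on the carbonyl carbon gives a number 16 percentage points lower from compound 1 to compound 4 (beyond the scatter), so the group on the carbonyl affects this read-out, as the groups on the aromatic ring were already seen to do. Nothing measured here explains why removing the phenyl has this effect. From the compounds shown here alone, whether an ethyl or a longer chain on the carbonyl would recover any of the lost inhibition remains open. So does whether a cyclohexyl or benzyl group could stand in for the phenyl.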